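Working notes: bromophenyl to hydroxyphenyl exchange

A few compounds are considered here, and "the series" means these few. Any claim that something is new, unique, unknown or untested is made for them only; others in the source may bear on it.

Values in an ADME assay on NHDF cells (Homo sapiens) for cytotoxicity, read by MTT assay, with a stated time of 72 h; a higher number here means a weaker inhibitor, a lower number a stronger inhibitor:
- compound 1 `COc1cccc(/C=C2\CCC/C(=C\c3cc(OC)c(OC)c(OC)c3)C2=O)c1OC`: 7900 nM
- compound 2 `COc1ccc(/C=C2\CCC/C(=C\c3ccccc3Br)C2=O)cc1OC`: 21800 nM
- compound 3 `COc1ccc(/C=C2\CCC/C(=C\c3ccc(Br)cc3)C2=O)cc1OC`: 13100 nM
- compound 4 `COc1ccc(/C=C2\CCC/C(=C\c3cccc(O)c3)C2=O)cc1OC`: not yet measured

Compound 3, at 13100 nM, holds the middle of the three numbers and lies within the scatter of both compound 1 and compound 2. The next change is 3-hydroxyphenyl in place of 4-bromophenyl on a double-bonded chain carbon bound to a double-bonded ring carbon, with 3-hydroxyphenyl in place of 4-bromophenyl on a double-bonded chain carbon bound to a double-bonded ring carbon. Among the measured compounds shown here, only one measured step bears on this, and only partly: a 1.7-fold lower number from compound 2 to compound 3 (0.22 log units; within the scatter). That step exchanges one bromophenyl for another. For the measured compounds named here, no measured compound carries 3-hydroxyphenyl, so the data do not show the size of this exchange directly. With that single small step as the guide, no shift beyond the scatter is expected in this assay, in either direction. The expected step is a 1.1-fold lower number from compound 3 to compound 4 (0.04 log units; within the scatter). For compound 4 the estimate is 12000 nM, with an expected range of 5000 nM to 28000 nM.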

Compound 4, half-maximal inhibitory concentration: 6800 nM
Compound 4: the middle estimate sits 1.8-fold (0.25 log units) above what was measured, and the stated range covers the measured number.
By their numbers in this assay, from the lowest: compounds 4, 1, 3 and 2 (each within the scatter of the next, the first and the last beyond it).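

In this assay, the exchange of 4-bromophenyl for 3-hydroxyphenyl gives a 1.9-fold lower number from compound 3 to compound 4 (0.28 log units; within the scatter), so on its own this change cannot be told apart from repeat scatter. Measured against the other bromophenyl, the same group gives a 3.2-fold lower number from compound 2 to compound 4 (0.51 log units; beyond the scatter), a modest step and the only one at this place on a double-bonded chain carbon that clears the scatter, showing that this position can register a change in this assay. The data shown offer no measured basis for explaining this step.

The compounds shown do not separate the effect of the hydroxyl itself from that of its place on the phenyl ring. As far as these compounds go, whether an amine or a carboxylic acid in place of the hydroxyl would give a similar number also remains open.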